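From a Ring to a Butyl Chain on the Sulfonamide

The source may hold more compounds than are shown below. What is called first, only, known or untested is meant among the compounds shown, and "the series" means these compounds.

In a toxicity assay on Vero cells (Chlorocebus sabaeus) for cytotoxicity, read by MTT assay (on this read-out lower numbers stand for stronger inhibition and higher numbers for weaker inhibition), compound 1 (`COC(=O)NC(=O)c1ccsc1NC(=O)c1ccc(S(=O)(=O)N2CCCC2)cc1`) gives 39.5 ug/mL, compound 2 (`COC(=O)NC(=O)c1ccsc1NC(=O)c1ccc(S(=O)(=O)N2CCCCCC2)cc1`) gives 9.13 ug/mL and compound 3 (`COC(=O)NC(=O)c1ccsc1NC(=O)c1ccc(S(=O)(=O)NC2CCOCC2)cc1`) gives 35.7 ug/mL. Compound 3 therefore stands level with compound 1, and both sit above compound 2.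

Compound 4 (`CCCCNS(=O)(=O)c1ccc(C(=O)Nc2sccc2C(=O)NC(=O)OC)cc1`) differs from compound 3 in one place: butyl in place of oxan-4-yl on a sulfonamide nitrogen. In words, butyl takes the place of oxan-4-yl on a sulfonamide nitrogen.

Among the measured compounds shown here, no measured step makes this exact change, so the evidence is indirect. Changes to the group on the sulfonyl sulfur gave a 1.1-fold lower number from compound 1 to compound 3 (0.04 log units; within the scatter), a 4.3-fold lower number from compound 1 to compound 2 (0.64 log units; beyond the scatter) and a 3.9-fold higher number from compound 2 to compound 3 (0.59 log units; beyond the scatter). These steps show that the number can stay put or shift modestly, and only compound 2 breaks away from the other two. None of them replaces a ring with an open chain. A small move towards a lower number is expected, estimated as a 1.6-fold lower number from compound 3 to compound 4 (0.21 log units; within the scatter), and this would not clearly exceed the scatter. For compound 4 the expected value is 22 ug/mL, with an estimated range from 9 ug/mL to 50 ug/mL.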

Compound 4, half-maximal inhibitory concentration: 29.5 ug/mL
Beside the measured number, compound 4's estimate is 1.3-fold (0.13 log units) below it; the measured number falls inside the stated range.
By their numbers in this assay, from the lowest: compound 2; then compounds 4, 3 and 1 (each within the scatter of the next).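

In this assay, putting butyl in place of oxan-4-yl on a sulfonamide nitrogen gives a 1.2-fold lower number from compound 3 to compound 4 (0.08 log units; within the scatter), so at this position an open chain with no ring and no oxygen reads the same as the ring within the scatter. Butylamino in place of pyrrolidin-1-yl on a sulfonyl sulfur gives a 1.3-fold lower number from compound 1 to compound 4 (0.13 log units; within the scatter), while butylamino in place of azepan-1-yl gives a 3.2-fold higher number from compound 2 to compound 4 (0.51 log units; beyond the scatter), which leaves compound 2 as the only one of the four apart from the rest. Nothing measured here explains why these groups on the sulfonyl sulfur read as they do.

As far as these compounds go, whether a longer chain such as hexyl would stay level with butyl or move towards compound 2 remains open. So does the reading of a butyl chain ending in an amine or a carboxylic acid.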